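Halogen exchange at the aryl ether: compound 3

The compounds below may be only part of what the source reports. "The series", "measured", "known", "first", "only" and "open" are said of these compounds alone.

Compound 1 `Cc1ccc(Oc2ccc3nncn3n2)cc1` reaches only a limit of the assay, > 100 mg/kg, in a functional assay on the whole organism with Mus musculus as the target; a higher number here means that more compound is needed for the effect, a lower number that less compound is needed. Within the data shown here, compound 2 `Fc1ccc(Oc2ccc3nncn3n2)cc1` gives 38 mg/kg in this assay, the only number in the set so far. Among the measured compounds shown here, the step of an at least 2.6-fold lower number from compound 1 to compound 2 (0.42 log units; beyond the scatter) is the single measured step, and it is read against (the limit of > 100 mg/kg in this assay, at which 1 of the 2 values shown sits). Compound 3 `Clc1ccc(Oc2ccc3nncn3n2)cc1` differs from compound 2 by chloro in place of fluoro on an aromatic carbon, a chloro in place of fluoro on an aromatic carbon, para to a large group. For the measured compounds named here, the measured step exchanged methyl for fluoro at this position and was at least modest; the chloro-for-fluoro exchange is a different swap, and no measured pair bears on it directly. A step within the scatter in this assay is expected for compound 3, with no clear direction, giving an estimated 1.1-fold higher number from compound 2 to compound 3 (0.02 log units; within the scatter). Compound 3 is thus expected at about 40 mg/kg, within 15 mg/kg to 100 mg/kg.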

Compound 3, dose for half-maximal effect: 36.7 mg/kg
For compound 3 the middle estimate is 1.1-fold (0.04 log units) above the measured one; low and high end bracket the measured number.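

In this assay, chloro in place of fluoro on this aromatic carbon, para to a large group, gives a 1.0-fold lower number from compound 2 to compound 3 (0.02 log units; within the scatter), so compound 2 and compound 3 cannot be told apart here. A second halogen now accompanies the gain over methyl, with an at least 2.7-fold lower number from compound 1 to compound 3 (0.43 log units; beyond the scatter), so the earlier step from methyl to fluoro no longer rests on fluoro alone. Compound 1 stands at a limit of the assay, so the full size of this step stays unknown: the limit of > 100 mg/kg in this assay, at which 1 of the 3 values shown sits.

From the compounds shown here alone, whether this level is shared by halogens in general remains open, as does the outcome with bromo, and a methoxy, nitrile or amine on the same carbon would show whether non-halogen groups can match compound 2 and compound 3. Going by these compounds, the effect of the same groups at other places on the aromatic ring also remains open.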